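The source may report more compounds than this note shows. Statements on the series, on what has been measured and on what is new or still open speak of the compounds shown alone.

Compound 1 `O=C(Nc1cc(-c2ccccc2)[nH]n1)c1cccnc1Cl` gives 6220 nM
Compound 2 `O=C(Nc1cc(-c2ccccc2)[nH]n1)c1cncc(Br)c1` gives 6880 nM
Compound 3 `O=C(Nc1cc(-c2ccccc2)[nH]n1)c1ccc(Cl)nc1` gives 6430 nM

These values come from a functional assay on WM 266-4 cells (Homo sapiens) for antiproliferative activity, read by MTT assay, with a stated time of 48 h (on this read-out higher numbers stand for weaker inhibition and lower numbers for stronger inhibition), and all lie within the scatter of one another, so compound 2 cannot be separated from the other two. Compound 4 `O=C(Nc1cc(-c2ccc(Br)cc2)[nH]n1)c1cncc(Br)c1` is still unmeasured. It differs from compound 2 by one change bromo in place of hydrogen on an aromatic carbon on the phenyl, which becomes 4-bromophenyl.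

The three measured steps all swap the group on the carbonyl carbon instead. They are a 1.1-fold higher number from compound 1 to compound 2 (0.04 log units; within the scatter) and a 1.0-fold higher number from compound 1 to compound 3 (0.01 log units; within the scatter) and a 1.1-fold lower number from compound 2 to compound 3 (0.03 log units; within the scatter) and each stays within the scatter. None of them tests the phenyl, so they offer only weak guidance and point in no direction. No shift beyond the scatter is therefore expected.

The expected change is a 1.3-fold lower number from compound 2 to compound 4 (0.10 log units; within the scatter) and no more. For compound 4 the estimated value is 5500 nM with an expected range from 2000 nM to 13000 nM.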

Compound 4, half-maximal inhibitory concentration: 8230 nM
For compound 4 the middle estimate is 1.5-fold (0.18 log units) below the measured one; measured number inside the range.
By their numbers in this assay, from the lowest: compounds 1, 3, 2 and 4 (each within the scatter of the next).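

In this assay, bromo in place of hydrogen on the aromatic carbon para to a large group gives a 1.2-fold higher number from compound 2 to compound 4 (0.08 log units; within the scatter) and stays within the scatter. For the compounds shown here, this is the first step here to test the phenyl rather than the group on the carbonyl carbon, and phenyl to 4-bromophenyl cannot be told apart from no change. Nothing available explains this result.

From the compounds shown here alone, whether a different group at this place, such as an amine or a carboxylic acid, would shift the number remains open. So does whether bromo would act alike with the pyridinyl groups of compound 1 and compound 3.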